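The source may report more compounds than this note shows. Statements on the series, on what has been measured and on what is new or still open speak of the compounds shown alone.

Measured compounds in an assay on LX2 cells for inhibition of COL1A1 promoter (Homo sapiens), read by a luciferase reporter, with a stated time of 24 h, tested at 50 uM; a higher number here means a stronger effect of the compound at the concentration tested, a lower number a weaker effect:
- compound 1 `Cc1cc(OCCCCCCC[N+]2(C)CCCC2)cc(-n2cc(C(=O)Nc3cc(F)cc(F)c3)c(=O)c3ccc(N(C)C)nc32)c1`: 35.4%
- compound 2 `CN(C)c1ccc2c(=O)c(C(=O)Nc3cc(F)cc(F)c3)cn(-c3ccc(OCCCCCCC[N+]4(C)CCCCC4)cc3Cl)c2n1`: "not active" (no number reported)
- compound 3 `CC[N+]1(CCCCCCCOc2ccc(-n3cc(C(=O)Nc4cc(F)cc(F)c4)c(=O)c4ccc(N(C)C)nc43)cc2C)CCCCC1`: 53.4%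

Compound 1 stands lowest of the two numbers in this assay; the nearest, compound 3, lies higher by a gap beyond the usual scatter, and compound 2 carries no number. Going by the values given here, no pair differing in a single place has been measured, so no step size is known. Compound 4 `Cc1cc(OCCCCCCC[N+]2(C)CCN(C)CC2)cc(-n2cc(C(=O)Nc3cc(F)cc(F)c3)c(=O)c3ccc(N(C)C)nc32)c1` differs from compound 1 by a group of 8 heavy atoms (6 carbon, 2 nitrogen; one six-membered non-aromatic ring with 2 hetero atoms) in place of a group of 6 heavy atoms (5 carbon, 1 nitrogen; one five-membered non-aromatic ring with 1 hetero atom), on a saturated chain carbon, seven bonds along the chain from an oxygen on an aromatic ring. With nothing comparable measured, only a small step is expected in this assay, if any, and more likely downward than upward; the expected step from compound 1 to compound 4 is a number 5.4 percentage points lower from compound 1 to compound 4 (within the scatter). Compound 4 is therefore estimated at 30%, within a range from 12% to 48%.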

Compound 4, a percentage reported as inhibition, at one concentration (the size of the read-out at that concentration, not a potency): 38.2%
Estimate against measurement, compound 4: 8.2 percentage points below, within the range that was stated.
By their numbers in this assay, from the lowest: compounds 1 and 4 (each within the scatter of the next); then compound 3.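

Replacing the five-membered non-aromatic ring with 1 hetero atom by the six-membered non-aromatic ring with 2 hetero atoms, on a saturated chain carbon, seven bonds along the chain from an oxygen on an aromatic ring, gives a number 2.8 percentage points higher from compound 1 to compound 4 (within the scatter) in this assay and so shows no readable change. This place therefore accepts a group with more heavy atoms and a second ring nitrogen, at the same net charge of +1, without a shift beyond the scatter. Nothing at hand explains this result. Still open, as far as these compounds go, is whether a neutral tertiary amine or a carboxylic acid at this place, or a longer chain, would move the read-out.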